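Removing a Methyl From a Weak Kinase Binder

This account rests on a few compounds, and the source may have more. Where it says the series, first, only, none or still open, it means among the compounds named here.

Compound 1 `NCC1CCN(c2ncnc3[nH]ccc23)CC1`: 770 nM
Compound 2 `Cc1nc2c(N3CCC(N)CC3)ncnc2[nH]1`: 110000 nM

In an assay on isolated protein for inhibition of RAC-beta serine/threonine-protein kinase (Homo sapiens), read by radiometric assay and filter binding (on this read-out lower numbers stand for stronger inhibition and higher numbers for weaker inhibition), compound 1 gives 770 nM, and compound 2 gives 110000 nM. Compound 2 therefore stands at the highest of the two numbers, weaker than compound 1 by a gap that lies far beyond the usual scatter. The two compounds are not related by a single change, so their numbers can only be set side by side, not traced to one structural feature.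

Compound 3 `NC1CCN(c2ncnc3[nH]cnc23)CC1` differs from compound 2 by hydrogen in place of methyl on an aromatic carbon. Among the compounds with values here, no measured pair shows this change, so any expectation rests on compound 2 alone. Compound 3 is expected to sit somewhat lower, the step being a 2.8-fold lower number from compound 2 to compound 3 (0.44 log units; beyond the scatter), likely near the edge of the scatter rather than clearly beyond it. Compound 3 is accordingly estimated at 40000 nM, with a range from 10000 nM to 150000 nM.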

Compound 3, half-maximal inhibitory concentration: 270 nM
For compound 3 the middle estimate is 150-fold (2.17 log units) above the measured one; measured number below the stated range.
By their numbers in this assay, from the lowest: compound 3; then compound 1; then compound 2.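

Taking the methyl off the aromatic carbon between two ring nitrogen atoms, with hydrogen in its place, gives a 410-fold lower number from compound 2 to compound 3 (2.61 log units; beyond the scatter) in this assay, a large change for the loss of one heavy atom. Within the data shown here, this is the first change that can be traced to a single place, since the earlier pair differed in more than one, and it shows that this position strongly affects the read-out. The compounds shown offer no measurement that explains the size of this step.

From the compounds shown here alone, what remains open is whether an ethyl, an amine or a chlorine on the same carbon would give a number nearer that of compound 2 or that of compound 3. Going by these compounds, the effect also rests on this one pair, so it is unknown whether the same change would behave alike on the core of compound 1.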